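A few compounds are considered here, and "the series" means these few. Any claim that something is new, unique, unknown or untested is made for them only; others in the source may bear on it.

Compound 1, `COc1ccccc1S(=O)(=O)/C=C/c1ccccn1`, was examined in an ADME assay on BV-2 cells (Mus musculus) for cytotoxicity, with a stated time of 24 h, tested at 10 uM (on this read-out lower numbers stand for a stronger effect and higher numbers for a weaker effect at the one concentration tested), where compound 1 gives 100%. Compound 2, `COc1ccccc1S(=O)(=O)/C=C/c1cccc(Cl)n1`, carries one alteration relative to compound 1, namely (chloro in place of hydrogen on an aromatic carbon), and in this assay compound 2 gives 100%. The step recorded for this alteration is no change at the digits printed from compound 1 to compound 2 (within the scatter).

Compound 3, `COc1ccc(S(=O)(=O)/C=C/c2ccccn2)cc1`, has a core that differs from the core of compound 1; the difference between the two cores is not broken down here. In this assay compound 3 gives 100%, level with compound 1 and compound 2.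

Compound 4, `COc1ccc(S(=O)(=O)/C=C/c2ccc(Cl)cn2)cc1`, has not yet been tested. It is related to compound 3 by chloro in place of hydrogen on an aromatic carbon. Among the measured compounds shown here, this is the same kind of change as the one between compound 1 and compound 2, but its place differs: here the chloro sits two atoms from the ring nitrogen and para to a large group, whereas in compound 2 it sits next to the ring nitrogen and meta to a large group. Because the earlier step of no change at the digits printed from compound 1 to compound 2 (within the scatter) showed no movement, the step expected in this assay is no change at the digits printed from compound 3 to compound 4 (within the scatter). Compound 4 is therefore estimated at 100%, between 88% and 108%.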

Compound 4, a percentage reported as activity, at one concentration (the size of the read-out at that concentration, not a potency): 100%
Beside the measured number, compound 4's estimate shows no gap at the digits printed; low and high end bracket the measured number.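

In this assay the new step reads no change at the digits printed from compound 3 to compound 4 (within the scatter), and set beside the earlier step, the same change on the second core gives the same result: the same change on two cores in this assay, no change at the digits printed (within the scatter) from compound 1 to compound 2 and no change at the digits printed (within the scatter) from compound 3 to compound 4, 0 percentage points apart, within the scatter of two such steps

This shows that, for these two pairs, chloro in place of hydrogen on an aromatic carbon left the read-out where it stood on both cores, even though the chloro occupies a different place on the ring in each pair. It does not show that the change would behave the same way on other cores or at other places on the ring, and two steps without movement cannot show whether a change that did move the read-out would carry across.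

Among the compounds shown, chloro is the only group that varies on the ring with one nitrogen. Going by these compounds, whether an amine, a carboxylic acid or a trifluoromethyl group there would lower the read-out remains open.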